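The compounds below may be only part of what the source reports. "The series", "measured", "known", "first", "only" and "open" are said of these compounds alone.

Compound 1 `COc1cc(NC(C)CCCNC(=O)/C=C/c2ccccc2F)c2ncccc2c1` and compound 2 `COc1cc(NC(C)CCCNC(=O)/C=C/c2cccc(C(F)(F)F)c2)c2ncccc2c1` share one core; compound 3 `COc1cc(NC(C)CCCNC(=O)NNC(=O)/C=C/c2ccccc2F)c2ncccc2c1` and the unmeasured compound 4 `COc1cc(NC(C)CCCNC(=O)NNC(=O)/C=C/c2cccc(C(F)(F)F)c2)c2ncccc2c1` share another. How the core of compound 3 differs from the core of compound 1 is not broken down here. In an ADME assay on L6 cells (Rattus norvegicus) for cytotoxicity, read by resazurin assay, with a stated time of 70 h (on this read-out higher numbers stand for weaker inhibition and lower numbers for stronger inhibition), compound 1 gives 3500 nM and compound 2 gives 16200 nM; the change 3-(trifluoromethyl)phenyl in place of 2-fluorophenyl on a double-bonded chain carbon bound to a double-bonded chain carbon thus makes a 4.6-fold higher number from compound 1 to compound 2 (0.67 log units; beyond the scatter). In this assay compound 3 gives 25100 nM, a higher number than compound 1 and within the scatter of compound 2. The change from compound 3 to compound 4 is 3-(trifluoromethyl)phenyl in place of 2-fluorophenyl on a double-bonded chain carbon bound to a double-bonded chain carbon, the same change as before, at the same place. The earlier step of a 4.6-fold higher number from compound 1 to compound 2 (0.67 log units; beyond the scatter) was modest, and compound 3 already stands at 25100 nM, so a smaller step is expected here. In this assay the expected step is a 2.0-fold higher number from compound 3 to compound 4 (0.30 log units; within the scatter). Compound 4 is therefore estimated at 50000 nM, with a likely range from 20000 nM to 150000 nM.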

Compound 4, half-maximal inhibitory concentration: 10600 nM
Beside the measured number, compound 4's estimate is 4.7-fold (0.67 log units) above it; measured number below the stated range.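

In this assay, replacing 2-fluorophenyl with 3-(trifluoromethyl)phenyl on the core of compound 3 gives a 2.4-fold lower number from compound 3 to compound 4 (0.37 log units; beyond the scatter), opposite in direction to the step on the core of compound 1. The effect of this change therefore does not carry from one core to the other in this series, and a step measured on one core gives no safe estimate of the step on the other: the same change on two cores in this assay, a 4.6-fold higher number (0.67 log units; beyond the scatter) from compound 1 to compound 2 and a 2.4-fold lower number (0.37 log units; beyond the scatter) from compound 3 to compound 4, 11-fold (1.04 log units) apart, beyond the scatter of two such steps

Among these compounds, with one matched pair on each core, this result covers only this one change in this one cytotoxicity read-out; it does not show which part of the difference between the cores goes with the reversal, or whether other changes at this place would also reverse.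

Still open, from the compounds shown here alone, is whether a chlorophenyl or a methoxyphenyl at the same place would follow the pattern of compound 1 and compound 2 or that of compound 3 and compound 4. Also open, going by these compounds, is how either pair would behave with a longer chain in the core.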